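This account rests on a few compounds, and the source may have more. Where it says the series, first, only, none or still open, it means among the compounds named here.

In a functional assay on KYSE-450 cells (Homo sapiens) for inhibition, read by CCK-8 assay, with a stated time of 48 h (on this read-out higher numbers stand for weaker inhibition and lower numbers for stronger inhibition), compound 2 (`COc1ccc(CN(C(=O)CSC(=S)N2CCN(C(=O)OC(C)(C)C)CC2)c2cc(OC)c(OC)c(OC)c2)cc1O`) gives 76 nM, the lower of the two numbers and beyond the scatter from compound 1 (`COc1ccc(CN(C(=O)CSC(=S)N2CCN(C)CC2)c2cc(OC)c(OC)c(OC)c2)cc1`), which gives 1250 nM. Going by the values given here, these two compounds differ in more than one place, so no single-change step has been measured. Compound 3 (`COc1ccc(CN(C(=O)CSC(=S)N2CCN(C)CC2)c2cc(OC)c(OC)c(OC)c2)cc1O`) departs from compound 2 by methyl in place of tert-butoxycarbonyl on an amine nitrogen in a ring. That methyl is also present in compound 1, at 1250 nM, so weaker inhibition is expected in this assay. The expected change, a moderate rise in the number, is estimated as a 2.9-fold higher number from compound 2 to compound 3 (0.46 log units; beyond the scatter). For compound 3 the estimate is 220 nM, within a range of 60 nM to 900 nM.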

Compound 3, half-maximal inhibitory concentration: 760 nM
Estimate against measurement, compound 3: 3.5-fold (0.54 log units) below; low and high end bracket the measured number.
By their numbers in this assay, from the lowest: compound 2; then compounds 3 and 1 (each within the scatter of the next).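

In this assay, going by these compounds alone, the swap to methyl on the amine nitrogen in the ring gives the first single-change reading at this position, and it weakens inhibition (a 10-fold higher number from compound 2 to compound 3 (1.00 log units; beyond the scatter)). With methyl on that nitrogen, hydroxy in place of hydrogen on an aromatic carbon leaves the number within the scatter (a 1.6-fold lower number from compound 1 to compound 3 (0.22 log units; within the scatter)). No measurement at hand accounts for the step at the nitrogen. Going by these compounds, whether the hydroxy matters with tert-butoxycarbonyl on that nitrogen remains open. So does how an acetyl group or a free amine there would read against compound 2 and compound 3.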